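The compounds below may be only part of what the source reports. "The series", "measured", "known", "first", "only" and "open" are said of these compounds alone.

Three compounds have been measured in a functional assay on SK-LU-1 cells (Homo sapiens) for antiproliferative activity, read by sulforhodamine B assay, with a stated time of 48 h, tested at 50 uM; on this read-out higher numbers stand for more inhibition at the one concentration tested (going by the name of the read-out) and lower numbers for less inhibition:

compound 1, `Cc1cc2c(C(C)C)ccc(C)c2cc1OC(=O)c1cccc(C(F)(F)F)c1`: 17.3%
compound 2, `CC1=CC[C@H](C(C)C)c2cc(C)c(OC(=O)Nc3ccccc3)cc21`: 100%
compound 3, `CC1=CC[C@H](C(C)C)c2cc(C)c(OC(=O)c3ccc([N+](=O)[O-])cc3)cc21`: 47.5%

Compound 1 stands lowest of the three in this assay; compound 3 lies nearest to it and compound 2 furthest, both beyond the scatter. Among the measured compounds shown here, the one step measured between neighbouring structures is a number 52.5 percentage points lower from compound 2 to compound 3 (beyond the scatter), a large drop that concerns the group carried on the carbonyl carbon.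

Compound 4, `COc1cccc(C(=O)Oc2cc3c(C)ccc(C(C)C)c3cc2C)c1`, is not yet measured. It differs from compound 1 in one place: methoxy in place of trifluoromethyl on an aromatic carbon. For the measured compounds named here, no measured step shares this change, since the step from compound 2 to compound 3 exchanges the whole group on the carbonyl carbon rather than one substituent on an aromatic ring that stays in place, and it involves a different core. The comparison therefore gives only a weak guide. Because compound 1 gives 17.3%, and nothing measured points to a rise or a fall for this exchange, compound 4 is expected to stay close to it, at 20% with a range of 5% to 40%, which means an expected step of a number 2.7 percentage points higher from compound 1 to compound 4 (within the scatter), within the scatter.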

Compound 4, a percentage reported as inhibition, at one concentration (the size of the read-out at that concentration, not a potency): 30.6%
Compound 4: the middle estimate sits 10.6 percentage points below what was measured; the measured number falls inside the stated range.
By their numbers in this assay, from the lowest: compound 1; then compound 4; then compound 3; then compound 2.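

In this assay, a single substituent exchange on an aromatic ring that stays in place, with methoxy in place of trifluoromethyl meta to a large group, gives a number 13.3 percentage points higher from compound 1 to compound 4 (beyond the scatter). This shows that the read-out responds to a change at this ring position, whereas the earlier step exchanged the whole group on the carbonyl carbon and involved a different core. No measured evidence explains why the number rises with this exchange.

The compounds shown leave open whether an amine or a hydroxyl group on the same aromatic carbon would raise the number further, and whether the step comes from gaining methoxy or from losing trifluoromethyl. They also leave open whether the same exchange would give a similar step on the core of compound 3.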